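A few compounds are considered here, and "the series" means these few. Any claim that something is new, unique, unknown or untested is made for them only; others in the source may bear on it.

Measured in a functional assay on UACC-62 cells (Homo sapiens) for cytotoxicity, read by sulforhodamine B assay; a lower number here means that less compound is tolerated, a higher number that more compound is tolerated:
- Compound 1 `CC1=CC[C@@H]([C@@](C)(O)CCCC(C)(C)NC(=S)N/N=C\c2ccc(N(C)C)cc2)CC1`: > 100000 nM (a limit, not a number)
- Compound 2 `CC1=CC[C@@H]([C@@](C)(O)CCCC(C)(C)NC(=S)N/N=C\c2cccc([N+](=O)[O-])c2)CC1`: 49300 nM

Going by the values given here, compound 2 gives the only actual number in this small set, 49300 nM. Compound 1 reaches only a limit of the assay, > 100000 nM. There is therefore no range of numbers against which to rank compound 2.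

The next compound, compound 3 `CC1=CC[C@@H]([C@@](C)(O)CCCC(C)(C)NC(=S)N/N=C\c2ccc([N+](=O)[O-])cc2)CC1`, has not yet been measured. It has the same atoms as compound 2, joined differently: 4-nitrophenyl in place of 3-nitrophenyl on a carbon with a double bond to nitrogen. In words, it carries 4-nitrophenyl in place of 3-nitrophenyl on a carbon with a double bond to nitrogen.

Among the compounds with values here, only one measured step bears on this change: an at least 2.0-fold lower number from compound 1 to compound 2 (0.30 log units; that floor lies within the scatter). As far as these compounds go, it swapped a different group at the same place, and it starts from the limit of > 100000 nM in this assay, at which 1 of the 2 values shown sits, so its true size is unknown. Even that larger swap is not shown to exceed the usual scatter, so no step beyond the scatter is expected in this assay.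

The expected step is a 1.0-fold higher number from compound 2 to compound 3 (0.01 log units; within the scatter). For compound 3 the estimated value is 50000 nM, with an expected range from 20000 nM to 100000 nM.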

Compound 3, concentration lethal to 50% of the cells: > 100000 nM
Compound 3: a limit, no number; the forecaster's own chance of this, stated with the estimate: 20%; middle value at least 2.0-fold (0.30 log units) from the limit.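

In this assay, 4-nitrophenyl in place of 3-nitrophenyl on a carbon with a double bond to nitrogen gives an at least 2.0-fold higher number from compound 2 to compound 3 (0.30 log units; that floor lies within the scatter). The earlier step exchanged one group for a quite different one at this place, whereas this change keeps the same atoms and only joins them differently, and it still separates a measured number from a limit, although the floor of the step lies within the scatter. Compound 3 gives > 100000 nM, which is a limit and not a number, so the true size of the step is unknown, the step between compound 1 and compound 3 cannot be read, and most of the set now rests on one limit: the limit of > 100000 nM in this assay, at which 2 of the 3 values shown sit.

Going by these compounds alone, compound 2 remains the only actual number in this assay, so it stays open whether moving the nitro group truly changes how much compound is tolerated beyond the scatter. As far as these compounds go, it is also open how a phenyl group carrying a nitrile or a carboxylic acid at this place would read in the same assay.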